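Benzyl Substitution on a Fused Core: Hamster Cell Inhibition

The source may hold more compounds than are shown below. What is called first, only, known or untested is meant among the compounds shown, and "the series" means these compounds.

The measured compounds:
compound 1, `CC(C)(C)NCc1cc(Cl)cc(Nc2nc3ccccc3n2Cc2ccc(C(F)(F)F)cc2)c1O`, 36300 nM
compound 2, `CC(C)(C)NCc1cc(Cl)cc(Nc2nc3ccccc3[nH]2)c1O`, a limit, > 50000 nM
compound 3, `Cc1cc(CNC(C)(C)C)c(O)c(Nc2nc3cc(F)c(F)cc3[nH]2)c1`, 16700 nM

In an ADME assay on CHO cells (Cricetulus griseus) for inhibition, read by MTT assay (a higher number here means a weaker inhibitor, a lower number a stronger inhibitor), compound 1 gives 36300 nM. Compound 2 reaches only the limit of this assay, > 50000 nM; this is the limit of > 50000 nM in this assay, at which 1 of the 3 values shown sits. The change between them, (4-(trifluoromethyl)benzyl in place of hydrogen on an aromatic nitrogen), made an at least 1.3-fold lower number from compound 2 to compound 1 (0.13 log units; that floor lies within the scatter). Compound 3 gives 16700 nM in this assay, the lowest of the two numbers; the difference between the core of compound 3 and that of compound 2 is not broken down here.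

Compound 4, `Cc1cc(CNC(C)(C)C)c(O)c(Nc2nc3cc(F)c(F)cc3n2Cc2ccc(C(F)(F)F)cc2)c1`, has not yet been measured in this assay. It arises from compound 3 by 4-(trifluoromethyl)benzyl in place of hydrogen on an aromatic nitrogen, the same change as from compound 2 to compound 1. Because that earlier step was an at least 1.3-fold lower number from compound 2 to compound 1 (0.13 log units; that floor lies within the scatter), one expects a 1.4-fold lower number from compound 3 to compound 4 (0.14 log units; within the scatter) from compound 3 to compound 4. For compound 4 the estimate in this assay is therefore 12000 nM, with a range from 4000 nM to 40000 nM.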

Compound 4, half-maximal inhibitory concentration: 10000 nM
Estimate against measurement, compound 4: 1.2-fold (0.08 log units) above, within the range that was stated.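

In this assay, placing 4-(trifluoromethyl)benzyl in place of hydrogen on an aromatic nitrogen of the core of compound 3 gave a 1.7-fold lower number from compound 3 to compound 4 (0.22 log units; within the scatter), so this pair on its own shows no change beyond the scatter. Set beside the earlier step, the change reads as small on both cores, but that is as far as the comparison goes: the same change on two cores in this assay, an at least 1.3-fold lower number (0.13 log units; that floor lies within the scatter) from compound 2 to compound 1 and a 1.7-fold lower number (0.22 log units; within the scatter) from compound 3 to compound 4; the limit leaves it open whether they differ The value of compound 2 is a limit of this assay and not a number: the limit of > 50000 nM in this assay, at which 1 of the 4 values shown sits. The series therefore shows that the change can be carried to a second core without a step beyond the scatter, and it does not show that the step has a fixed size.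

The compounds shown leave open whether a plain benzyl, a longer chain ending in an amine or a carboxylic acid on the same aromatic nitrogen would give a step beyond the scatter. No pair shown isolates the differences between the core of compound 2 and the core of compound 3, and these stay open as well.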